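Adding Two Fluorines to a Weak Antiproliferative Compound

The source may report more compounds than this note shows. Statements on the series, on what has been measured and on what is new or still open speak of the compounds shown alone.

Going by the values given here, in a functional assay on MCF7 cells (Homo sapiens) for antiproliferative activity (on this read-out lower numbers stand for stronger inhibition and higher numbers for weaker inhibition), compound 1 `CO[C@@H]1[C@@H](O)[C@@H](O)[C@H](Oc2ccc3c(c2C)OC(=O)C(n2cc(-c4ccccc4)nn2)C3)OC1(C)C` gives 64400 nM, the higher of the two numbers available so far and therefore the weaker result. Compound 2 `Cc1ccc(-c2cn(-c3cc4ccc(O)c(C)c4oc3=O)nn2)cc1` gives 23200 nM, a lower number by more than the usual scatter of repeated measurements. These two structures differ in more than one place, so their gap cannot be tied to any single group.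

The next structure, compound 3 `CO[C@@H]1[C@@H](O)[C@@H](O)[C@H](Oc2ccc3c(c2C)OC(=O)C(n2cc(-c4ccc(F)cc4F)nn2)C3)OC1(C)C`, keeps the core of compound 1 but carries 2,4-difluorophenyl in place of phenyl on an aromatic carbon. Among the compounds with values here, no measured pair of compounds shows a change of this kind, so the data offer no direct guide to its size in this assay. The expected result, a 1.4-fold lower number from compound 1 to compound 3 (0.16 log units; within the scatter), is a small move toward stronger inhibition, possibly no larger than the scatter. For compound 3 the estimated value is 45000 nM, with an expected range of 18000 nM to 100000 nM.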

Compound 3, half-maximal inhibitory concentration: > 100000 nM
Compound 3: only a limit was reported (the forecaster's own chance of this, stated with the estimate: 15%); middle value at least 2.2-fold (0.34 log units) away from the limit.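

On the five-membered aromatic ring, 2,4-difluorophenyl in place of phenyl gives an at least 1.5-fold higher number from compound 1 to compound 3 (0.19 log units; that floor lies within the scatter), the first view of what a change at this position does in this assay. The result for compound 3 is a limit of the assay, not a number: the limit of > 100000 nM in this assay, at which 1 of the 3 values shown sits. The earlier compounds shown here gave no reading of a change at this position, and this one shows no gain in inhibition from adding the two fluorines, though the smallest step consistent with the limit cannot be told apart from the scatter.

From the compounds shown here alone, the true size of the step remains unknown, so how much weaker compound 3 may be is open. Also open, going by these compounds, is whether a single fluorine, a methoxy group or an amine on the phenyl ring would shift the number in either direction.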